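The source may report more compounds than this note shows. Statements on the series, on what has been measured and on what is new or still open speak of the compounds shown alone.

Working notes on the carbamate series.

Three compounds share the core and differ only in the group on the carbonyl carbon of the piperidine carbamate. Compound 1 `Cc1nc(S(C)(=O)=O)ccc1Oc1ncnc(OC2CCN(C(=O)OC(C)C)CC2)c1F` gives 21 nM in a functional assay on isolated protein for inhibition of Glucose-dependent insulinotropic receptor (Homo sapiens), read by HTRF and cAMP accumulation; on this read-out higher numbers stand for an effect only at larger amounts of compound and lower numbers for an effect already at smaller amounts. Compound 2 `Cc1nc(S(C)(=O)=O)ccc1Oc1ncnc(OC2CCN(C(=O)O[C@H](C)CF)CC2)c1F` gives 196 nM in this assay, and compound 3 `Cc1nc(S(C)(=O)=O)ccc1Oc1ncnc(OC2CCN(C(=O)O[C@@H](C)C(F)(F)F)CC2)c1F` gives 9.86 nM, the lowest of the three numbers; its steps to both others lie beyond the scatter.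

The measured steps all concern the alkoxy part of the carbamate: a 9.3-fold higher number from compound 1 to compound 2 (0.97 log units; beyond the scatter); a 2.1-fold lower number from compound 1 to compound 3 (0.33 log units; beyond the scatter); a 20-fold lower number from compound 2 to compound 3 (1.30 log units; beyond the scatter). Adding a single fluorine to the isopropyl chain worsened the number markedly, whereas three fluorines on the same carbon improved it modestly.

Compound 4 `Cc1nc(S(C)(=O)=O)ccc1Oc1ncnc(OC2CCN(C(=O)SC3CC3)CC2)c1F` takes a different direction: a group of 4 heavy atoms (3 carbon, 1 sulfur; one three-membered non-aromatic ring of carbon only) in place of a group of 7 heavy atoms (3 carbon, 1 oxygen, 3 fluorine; no ring), on a carbonyl carbon. For the measured compounds named here, no measured pair exchanges the oxygen of the carbamate for sulfur or brings in a ring, so the three steps bear only indirectly, by showing that this position tolerates small branched groups with numbers that stay in the same general region in this assay. The cyclopropyl group is closest in size to the isopropyl of compound 1, which gave 21 nM. On that basis compound 4 is expected to show a 2.5-fold higher number from compound 3 to compound 4 (0.40 log units; beyond the scatter). Compound 4 is therefore estimated at 25 nM, with a range of 7 nM to 90 nM.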

Compound 4, half-maximal effective concentration: 24.9 nM
The estimate for compound 4 lay 1.0-fold (0.00 log units) above the measured number, within the range that was stated.
By their numbers in this assay, from the lowest: compound 3; then compounds 1 and 4 (each within the scatter of the next); then compound 2.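

Working notes, continued. In this assay the group on the carbonyl carbon need not be an alkoxy chain: with sulfur and a three-membered ring in place of the oxygen and isopropyl of compound 1, the series shows a 1.2-fold higher number from compound 1 to compound 4 (0.07 log units; within the scatter) as the step, so compound 4 and compound 1 cannot be told apart on this read-out. The same group leaves compound 4 on the compound 1 side of the fluorinated pair, with a 2.5-fold higher number from compound 3 to compound 4 (0.40 log units; beyond the scatter) on one side and a 7.9-fold lower number from compound 2 to compound 4 (0.90 log units; beyond the scatter) on the other, so the order of compound 3 ahead of this level and compound 2 behind it holds for a ring-bearing, sulfur-linked group as well as for the isopropyl chain. No measurement is available that would explain any of these steps.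

From the compounds shown here alone, compound 4 brings in the sulfur and the ring together, so their separate contributions stay open; a cyclopropoxy group and an isopropylthio group on the same carbonyl carbon would divide them. Going by these compounds, how an amine or a longer alkyl chain would read at this place also remains open.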